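The compounds below may be only part of what the source reports. "The series", "measured", "known", "first", "only" and "open" are said of these compounds alone.

Measured so far in a physicochemical assay for solubility, read by turbidimetry, measured as kinetic solubility, at pH 6.8; on this read-out lower numbers stand for lower solubility and higher numbers for higher solubility

compound 1 `COc1ccc(F)cc1N1C(=O)CSC1c1cccc(C(=O)NCCCCn2cccn2)c1` gives 50000 nM
compound 2 `O=C(NCCCCn1cccn1)c1cccc(C2SCC(=O)N2c2ccccn2)c1` gives 50000 nM
compound 3 `Cc1ccnc(N2C(=O)CSC2c2cccc(C(=O)NCCCCn3cccn3)c2)c1` gives 50000 nM

Level with compound 1 and compound 2 in this assay, compound 3 gives 50000 nM and so has no measured neighbour on either side of it. The next compound, compound 4 `O=C(NCCCCn1cccn1)c1cccc(C2SCC(=O)N2c2cc(F)ccn2)c1`, comes from it by one exchange: fluoro in place of methyl on an aromatic carbon in words fluoro in place of methyl on an aromatic carbon, opposite the ring nitrogen.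

The nearest measured evidence is no change at the digits printed from compound 2 to compound 3 (within the scatter) with methyl in place of hydrogen on an aromatic carbon. Two larger exchanges on the amide-type nitrogen point the same way: no change at the digits printed from compound 1 to compound 2 (within the scatter) with pyridin-2-yl entering and no change at the digits printed from compound 1 to compound 3 (within the scatter) with 4-methylpyridin-2-yl entering. None of the three moved the read-out. Among the compounds with values here, no measured step exchanges methyl for fluoro, so this particular swap remains untested, and the series holds only three flat values to go on. No shift in either direction is therefore expected, and the expected size is no change at the digits printed from compound 3 to compound 4 (within the scatter) and thus nothing beyond the scatter. Compound 4 is expected at 50000 nM with an estimated range from 25000 nM to 60000 nM in this read-out.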

Compound 4, solubility: 50000 nM
Compound 4: the middle estimate sits on the measured number at the digits printed; the range from low to high includes it.
By their numbers in this assay, from the lowest: compounds 1, 2, 3 and 4 (each within the scatter of the next).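

In this assay the carbon opposite the ring nitrogen now carries a third substituent, and fluoro in place of methyl gives the same picture as the earlier exchanges (no change at the digits printed from compound 3 to compound 4 (within the scatter)). Compounds 2 and 3 had covered only hydrogen and methyl at this carbon, whereas the comparison with the unsubstituted pyridin-2-yl compound now extends to fluoro (no change at the digits printed from compound 2 to compound 4 (within the scatter)), and exchanging the 5-fluoro-2-methoxyphenyl group for 4-fluoropyridin-2-yl on the amide-type nitrogen also leaves the printed value as it was (no change at the digits printed from compound 1 to compound 4 (within the scatter)). No measurement at hand offers an explanation for this flat result.

With all four compounds at one printed value, the compounds shown do not identify any change that moves this read-out. Going by these compounds, it remains open whether an amine or a carboxylic acid on the carbon opposite the ring nitrogen, or a longer chain in place of the one that carries the pyrazole, would separate a compound from this group in this assay.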